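Pyridin-4-yl Replaces Hydroxymethylphenyl in Compound 4

The source may hold more compounds than are shown below. What is called first, only, known or untested is meant among the compounds shown, and "the series" means these compounds.

Measured compounds:
compound 1 `O=[N+]([O-])c1c(CS(=O)(=O)c2ccccc2)nc2c(-c3ccc(O)cc3)cc(Cl)cn12` — > 12500 nM
compound 2 `O=[N+]([O-])c1c(CS(=O)(=O)c2ccccc2)nc2c(-c3ccc(CO)cc3)cc(Cl)cn12` — 13100 nM
compound 3 `O=[N+]([O-])c1c(CS(=O)(=O)c2ccccc2)nc2c(-c3cccc(C(F)(F)F)c3)cc(Cl)cn12` — > 12500 nM

Going by the values given here, in an ADME assay on HepG2 cells (Homo sapiens) for cytotoxicity, read by MTT assay, with a stated time of 72 h (a higher number here means that more compound is tolerated, a lower number that less compound is tolerated), compound 2 gives 13100 nM, the only value reported as a number. For compound 1 the value > 12500 nM is a limit of the assay. For compound 3 the value > 12500 nM is likewise a limit. The steps a step that the limit leaves unreadable from compound 1 to compound 2 and a step that the limit leaves unreadable from compound 2 to compound 3 cannot be sized because the limit of > 12500 nM in this assay, at which 2 of the 3 values shown sit, caps the values of the neighbours of compound 2.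

Compound 4 `O=[N+]([O-])c1c(CS(=O)(=O)c2ccccc2)nc2c(-c3ccncc3)cc(Cl)cn12` differs from compound 2 in one place: pyridin-4-yl in place of 4-(hydroxymethyl)phenyl on an aromatic carbon. Among the compounds with values here, no measured step covers this change. Since compound 2 already sits close to the limit and both of its neighbours rest at it, compound 4 is expected to show a step of a 1.0-fold lower number from compound 2 to compound 4 (0.02 log units; within the scatter) in this assay, that is none beyond the scatter. The estimate for compound 4 is 12500 nM, with a range from 6000 nM to 26000 nM.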

Compound 4, half-maximal cytotoxic concentration: > 50000 nM
Compound 4: a limit, no number (the forecaster's own chance of this, stated with the estimate: 55%); middle value at least 4.0-fold (0.60 log units) away from the limit.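

In this assay, pyridin-4-yl on this aromatic carbon gives an at least 3.8-fold higher number from compound 2 to compound 4 (0.58 log units; beyond the scatter), the only step among these compounds that can be read. Compound 4 gives > 50000 nM, which is a limit of the assay and not a number. The steps to compound 4 from compound 1 and from compound 3 cannot be read: the limit of > 12500 nM in this assay, at which 2 of the 4 values shown sit.

The compounds shown leave open how far the value of compound 4 lies past its limit. They also leave open whether pyridin-3-yl or 4-aminophenyl on the same carbon would give a step of similar size.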